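The source may hold more compounds than are shown below. What is called first, only, known or untested is meant among the compounds shown, and "the series" means these compounds.

Working notes on the series, all read in a functional assay on the whole organism (strain Wistar albino) for inhibition, with Rattus norvegicus as the target, read by paw edema, with stated times of 1 h and 2 h, at a dose of 0.32 mmol/kg by the intraperitoneal route; a lower number here means less inhibition, a higher number more inhibition at the dose given (going by the name of the read-out). Compound 1 `COc1ccc(-c2nn(-c3ccc(Cl)cc3)cc2C=O)cc1` gives 63.1%, compound 2 `Cc1ccc(-c2nn(-c3ccc(S(N)(=O)=O)cc3)cc2C=O)cc1` gives 58.4%, and compound 3 `COc1ccc(/N=C\c2cn(-c3ccc(Cl)cc3)nc2-c2ccc(OC)cc2)cc1` gives 69.2%. Compound 2 stands lowest of the three numbers: compound 1 lies within the scatter of it, compound 3 beyond it. Among the compounds with values here, compound 4 `Cc1ccc(-c2nn(-c3ccc(S(N)(=O)=O)cc3)cc2/C=N\c2ccc(Cl)cc2)cc1` is not yet measured; against compound 2 it shows this change: a group of 9 heavy atoms (7 carbon, 1 nitrogen, 1 chlorine; one six-membered aromatic ring of carbon only) in place of a group of 2 heavy atoms (1 carbon, 1 oxygen; no ring), on an aromatic carbon The one measured step that bears on it, a number 6.1 percentage points higher from compound 1 to compound 3 (within the scatter), is of the same kind, a larger group with one six-membered aromatic ring of carbon only in place of formyl, and it stayed within the scatter. For compound 4 a step of a number 4.6 percentage points higher from compound 2 to compound 4 (within the scatter) is therefore expected, not beyond the scatter. Compound 4 is estimated at 63%, in the range 54% to 72%.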

Compound 4, a percentage reported as inhibition, in the whole organism at one dose (the size of the read-out at that dose, not a potency): 69.1%
Beside the measured number, compound 4's estimate is 6.1 percentage points below it; the measured number falls inside the stated range.
By their numbers in this assay, from the lowest: compounds 2, 1, 4 and 3 (each within the scatter of the next, the first and the last beyond it).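

In this assay, the larger group with one six-membered aromatic ring of carbon only in place of formyl, on this aromatic carbon of the five-membered ring, now gives a step beyond the scatter: a number 10.7 percentage points higher from compound 2 to compound 4 (beyond the scatter). The step of the same kind, a number 6.1 percentage points higher from compound 1 to compound 3 (within the scatter), stayed within it, so the change can raise the read-out measurably, though only in this one pair. No available data explain the step.

On these data alone, whether a carboxylic acid or a simple amine at this position would hold the read-out at this level stays open.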